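The compounds below may be only part of what the source reports. "The series", "measured", "known", "first", "only" and "open" are said of these compounds alone.

Compound 1 `CN(C)CCCn1nc(C2=C(c3cn(C)c4ccccc34)C(=O)NC2=O)c2cccnc21` is the simplest member of the set here. In a functional assay on A549 cells (Homo sapiens) for antiproliferative activity, read by MTT assay, with a stated time of 48 h (a lower number here means a stronger inhibitor, a higher number a weaker inhibitor), compound 1 gives only a limit, > 100000 nM, and so stands without a proper number; (the limit of > 100000 nM in this assay, at which 1 of the 3 values shown sits). Going by the values given here, compound 2 `Cn1cc(C2=C(c3nn(CCCn4ccnc4)c4ncccc34)C(=O)N(c3ccccc3)C2=O)c2ccccc21` gives 1560 nM in this assay, and compound 3 `COc1ccc(N2C(=O)C(c3cn(C)c4ccccc34)=C(c3nn(CCCN4CCCCC4)c4ncccc34)C2=O)cc1` gives 30300 nM; neither differs from compound 1 in a single place, so no measured step connects them to it. Compound 4 `Cn1cc(C2=C(c3nn(CCCN4CCCCC4)c4ncccc34)C(=O)NC2=O)c2ccccc21` differs from compound 1 as follows: piperidin-1-yl in place of dimethylamino on a saturated chain carbon, three bonds along the chain from an aromatic nitrogen. Compound 3 carries the same piperidin-1-yl chain and gives 30300 nM in this assay, so the step of an at least 2.0-fold lower number from compound 1 to compound 4 (0.30 log units; that floor lies within the scatter) is expected to run toward a stronger inhibitor, though only modestly and with wide uncertainty. Compound 4 is accordingly estimated at 50000 nM, within 10000 nM to 150000 nM.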

Compound 4, half-maximal inhibitory concentration: > 100000 nM
Compound 4: no number, only a limit; the forecaster's own chance of this, stated with the estimate: 35%; middle value at least 2.0-fold (0.30 log units) from the limit.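

The step in this assay between compound 1 and compound 4 cannot be read, both values being limits, so piperidin-1-yl in place of dimethylamino shows no readable effect here. The readable step is an at least 3.3-fold higher number from compound 3 to compound 4 (0.51 log units; beyond the scatter), with hydrogen in place of 4-methoxyphenyl on an amide-type nitrogen in a ring. Hydrogen on that nitrogen goes with the limit in compound 1 and compound 4: the limit of > 100000 nM in this assay, at which 2 of the 4 values shown sit.

Still open, going by these compounds, is how dimethylamino and piperidin-1-yl compare with 4-methoxyphenyl kept on that nitrogen. Also open, on these data alone, is how a benzyl group there would read.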